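The source may hold more compounds than are shown below. What is called first, only, known or untested is meant among the compounds shown, and "the series" means these compounds.

In a functional assay on HL-60 cells (Homo sapiens) for antiproliferative activity, read by XTT assay, with a stated time of 72 h (a higher number here means a weaker inhibitor, a lower number a stronger inhibitor), compound 1 `C#Cc1cn([C@@H]2O[C@H](CO)[C@@H](O)[C@H]2O)c2ncnc(N(C)C)c12` gives 290 nM. Compound 2 `Cc1ncnc2c1c(-c1ccoc1)cn2[C@@H]1O[C@H](CO)[C@@H](O)[C@H]1O` is recorded only as a limit of the assay, > 15000 nM. Compound 3 `Nc1nc(N)c2c(-c3ccco3)cn([C@@H]3O[C@H](CO)[C@@H](O)[C@H]3O)c2n1` is also recorded only as a limit, > 20000 nM, so no number fixes its place, and it sits at the far end of the values shown. Compound 4 `Nc1nc(N)c2c(-c3cccs3)cn([C@@H]3O[C@H](CO)[C@@H](O)[C@H]3O)c2n1` has thiophen-2-yl in place of furan-2-yl on an aromatic carbon of the five-membered aromatic ring, (thiophen-2-yl in place of furan-2-yl on an aromatic carbon). Among the compounds with values here, no measured pair shows what this exchange does in this assay, so no change beyond the scatter is expected, and the expected step is a number no higher from compound 3 to compound 4 (the limit leaves the size open). Compound 4 is estimated at 20000 nM, with an expected range of 5000 nM to 50000 nM.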

Compound 4, half-maximal inhibitory concentration: > 20000 nM
Compound 4 ended at the assay's limit (the forecaster's own chance of this, stated with the estimate: 75%); the middle value lies on the limit itself.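

In this assay compound 3 is recorded only as a limit, > 20000 nM. Within the data shown here, compound 4 is also only a limit, > 20000 nM, so no step from compound 3 to compound 4 can be read. The compounds shown leave open what thiophen-2-yl in place of furan-2-yl does in this assay.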